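The source may report more compounds than this note shows. Statements on the series, on what has been measured and on what is new or still open speak of the compounds shown alone.

Compound 1 `CSc1nc(NCc2ccc(-c3ccccn3)cc2)c2[nH]nc(C(C)C)c2n1` is the point of departure. In a functional assay on HT cells (Homo sapiens) for antiproliferative activity, read by fluorescence, with a stated time of 72 h (a lower number here means a stronger inhibitor of growth, a higher number a weaker inhibitor of growth), compound 1 gives 783 nM, the second highest of the three numbers measured: compound 3 `CC(C)c1n[nH]c2c(NCc3ccc(-c4ccccn4)cc3)nc(S)nc12` gives 2760 nM, and compound 2 `CC(C)c1n[nH]c2c(NCc3ccc(-c4ccccn4)cc3)nc(SCCCN(C)C)nc12` gives 105 nM.

Compound 4 `CC(C)c1n[nH]c2c(NCc3ccc(-c4ccccn4)cc3)nc(SCCO)nc12` differs from compound 1 in one place: hydroxymethyl in place of hydrogen on a saturated chain carbon bound to a sulfur.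

Within the data shown here, two measured steps bear on this. Lengthening the chain on the sulfur gave a 7.5-fold lower number from compound 1 to compound 2 (0.87 log units; beyond the scatter), while shortening it gave a 3.5-fold higher number from compound 1 to compound 3 (0.55 log units; beyond the scatter). Both point the same way: the longer the chain on the sulfur, the lower the number. Among the measured compounds shown here, the chain entering in compound 4 is shorter than the one in compound 2 and carries a hydroxyl rather than a dimethylamino group, so the step from compound 1 is expected to be a lower number, but smaller than a 7.5-fold lower number from compound 1 to compound 2 (0.87 log units; beyond the scatter).

For compound 4 the expected value in this assay is 350 nM, with a range of 150 nM to 900 nM, which corresponds to an expected step of a 2.2-fold lower number from compound 1 to compound 4 (0.35 log units; beyond the scatter).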

Compound 4, concentration for 50% growth inhibition: 48 nM
Compound 4: the middle estimate sits 7.3-fold (0.86 log units) above what was measured; measured number outside the range, below it.
By their numbers in this assay, from the lowest: compound 4; then compound 2; then compound 1; then compound 3.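

Placing a 2-hydroxyethyl on the sulfur gives a 16-fold lower number from compound 1 to compound 4 (1.21 log units; beyond the scatter) and a 58-fold lower number from compound 3 to compound 4 (1.76 log units; beyond the scatter), so this position can take a chain without a dimethylamino group and still give a low number. The earlier trend of longer chain, lower number does not hold across all the compounds: compound 4 goes against it, since replacing the (dimethylamino)methyl of compound 2 with hydroxy shortens the chain yet gives a 2.2-fold lower number from compound 2 to compound 4 (0.34 log units; beyond the scatter). Nothing measured here explains why this change works so well.

On these data alone, it remains open whether a 3-hydroxypropyl or a 2-methoxyethyl on the sulfur would give a number as low as that of compound 4. A 2-(dimethylamino)ethyl would show how the amine behaves on a chain of this shorter length.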